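This account rests on a few compounds, and the source may have more. Where it says the series, first, only, none or still open, it means among the compounds named here.

Values in an assay on HEK293 cells for negative allosteric modulation of metabotropic glutamate receptor 5 (Homo sapiens), read by FLIPR, with a stated time of 1 h (on this read-out higher numbers stand for weaker inhibition and lower numbers for stronger inhibition), for the measured compounds of the series:

compound 1, `CCN1CCc2nc(C#Cc3ccccc3)sc2C1`: 1200 nM
compound 2, `CCCCN1CCc2nc(C#Cc3ccccc3)sc2C1`: a limit of the assay, > 10000 nM
compound 3, `CC(C)S(=O)(=O)N1CCc2nc(C#Cc3ccccc3)sc2C1`: 11 nM

Compound 3 gives the lowest of the two numbers. The nearest number is that of compound 1, and the step of a 110-fold lower number from compound 1 to compound 3 (2.04 log units; beyond the scatter) is large. Compound 2 contributes only a limit of > 10000 nM in this assay, at which 1 of the 3 values shown sits, and so enters only as a bound; the step of an at least 900-fold lower number from compound 2 to compound 3 (2.95 log units; beyond the scatter) is large.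

Compound 4, `O=S(=O)(C1CCCCC1)N1CCc2nc(C#Cc3ccccc3)sc2C1`, keeps the sulfonamide of compound 3 and changes the group on the sulfur: cyclohexyl in place of isopropyl on a sulfonyl sulfur. Going by the values given here, none of the measured steps alters this group. The steps that have been measured all concern the substituent on the ring nitrogen: an at least 8.3-fold higher number from compound 1 to compound 2 (0.92 log units; beyond the scatter) is at least modest, while a 110-fold lower number from compound 1 to compound 3 (2.04 log units; beyond the scatter) and an at least 900-fold lower number from compound 2 to compound 3 (2.95 log units; beyond the scatter), which bring in the isopropylsulfonyl, are large. What these steps show is that the sulfonyl on the nitrogen carries the gain; they say nothing about exchanging one alkyl on the sulfur for another.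

For compound 4 the expectation is therefore a value in this assay close to that of compound 3, with a step of a 1.4-fold higher number from compound 3 to compound 4 (0.13 log units; within the scatter) that is not expected to exceed the scatter. Compound 4 is estimated at 15 nM, in the range 4 nM to 60 nM.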

Compound 4, half-maximal inhibitory concentration: 480 nM
Compound 4: the middle estimate sits 32-fold (1.51 log units) below what was measured; measured number above the stated range.
By their numbers in this assay, from the lowest: compound 3; then compound 4; then compound 1. At a limit, above all of these: compound 2.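

In this assay, the group on the sulfonyl sulfur proves to matter in its own right: cyclohexyl in place of isopropyl gives a 44-fold higher number from compound 3 to compound 4 (1.64 log units; beyond the scatter), so the sulfonyl on the ring nitrogen does not by itself secure the low number of compound 3. The earlier steps shown here all changed the substituent on the ring nitrogen, whereas this one keeps that sulfonamide nitrogen in a ring and changes only what the sulfur carries: 6 heavy atoms and a six-membered non-aromatic ring of carbon enter, 3 heavy atoms with no ring leave, and neither group has hydrogen-bond donors, hydrogen-bond acceptors or a net charge. Nothing among the data shown gives a reason for this step.

With a single exchange at this position, the added carbon count and the ring cannot be told apart, and an open-chain hexyl group on the sulfur would be needed to separate them. Going by these compounds, whether a smaller methyl or cyclopropyl group, a phenyl ring, or a group carrying an amine on the sulfur would give a number nearer that of compound 3 or of compound 4 also remains open.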